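Swapping the nitro for a para methoxy on the rhodanine ring

The source may report more compounds than this note shows. Statements on the series, on what has been measured and on what is new or still open speak of the compounds shown alone.

Measured so far:
Compound 1 `COc1cccc(N2C(=O)/C(=C/c3cc(C)n(-c4cccc(-c5nnn[nH]5)c4)c3C)SC2=S)c1`: 40600 nM
Compound 2 `Cc1cc(/C=C2\SC(=S)N(c3cccc([N+](=O)[O-])c3)C2=O)c(C)n1-c1cccc(-c2nnn[nH]2)c1`: 77000 nM

Of the compounds shown here, two have been tested in an ADME assay on MT2 cells (Homo sapiens) for cytotoxicity, read by XTT assay, with a stated time of 4 days; a lower number here means that less compound is tolerated, a higher number that more compound is tolerated. Compound 2 stands alongside compound 1: the step of a 1.9-fold higher number from compound 1 to compound 2 (0.28 log units; within the scatter) does not go beyond the scatter. Compound 3 `COc1ccc(N2C(=O)/C(=C/c3cc(C)n(-c4cccc(-c5nnn[nH]5)c4)c3C)SC2=S)cc1` has not been measured. Compared with compound 2, the change is 4-methoxyphenyl in place of 3-nitrophenyl on an amide-type nitrogen in a ring. Among the measured compounds shown here, only one measured step bears on it, a 1.9-fold higher number from compound 1 to compound 2 (0.28 log units; within the scatter), which exchanged a methoxy for a nitro at a different place on the same ring and stayed within the scatter. So compound 3 is expected to give 50000 nM, between 20000 nM and 120000 nM, a step of a 1.5-fold lower number from compound 2 to compound 3 (0.19 log units; within the scatter) that is estimated to stay within the scatter.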

Compound 3, half-maximal cytotoxic concentration: 87000 nM
The estimate for compound 3 lay 1.7-fold (0.24 log units) below the measured number; low and high end bracket the measured number.
By their numbers in this assay, from the lowest: compounds 1, 2 and 3 (each within the scatter of the next, the first and the last beyond it).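

In this assay, 4-methoxyphenyl in place of 3-nitrophenyl on the amide-type nitrogen in a ring gives a small step (a 1.1-fold higher number from compound 2 to compound 3 (0.05 log units; within the scatter)), so two quite different aryl groups read alike at this position. Among the compounds shown here, changing only where the methoxy sits, 4-methoxyphenyl in place of 3-methoxyphenyl, gives the one step here beyond the scatter, and it is modest (a 2.1-fold higher number from compound 1 to compound 3 (0.33 log units; beyond the scatter)). Nothing available explains that step. The aryl groups shown carry only nitro or methoxy, so the effect of an amine or a carboxylic acid on that ring remains open.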